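Removing a chain chloro: expected cytotoxicity of compound 3

This account rests on a few compounds, and the source may have more. Where it says the series, first, only, none or still open, it means among the compounds named here.

Compound 1, `CCCSc1nnc(Cc2ccc(Cl)cc2Cl)o1`, in a functional assay on HepG2 cells (Homo sapiens) for cytotoxicity, with a stated time of 5 days (on this read-out higher numbers stand for lower toxicity in this test and lower numbers for higher toxicity in this test), gives > 50000 nM; this value is a limit of the assay, not a number.
Compound 2, `O=[N+]([O-])c1cccc(OCc2nnc(SCCCCl)o2)c1`, in this assay gives > 50000 nM; this value too is a limit of the assay, not a number.

Compound 2 thus sits at the boundary of what this assay can report, the point at which both measured compounds stand (the limit of > 50000 nM in this assay, at which 2 of the 2 values shown sit). For the measured compounds named here, no step between measured compounds is available, so nothing measured shows what a change on the chain does here. Compound 3, `CCCSc1nnc(COc2cccc([N+](=O)[O-])c2)o1`, differs from compound 2 in one place: hydrogen in place of chloro on a saturated chain carbon, three bonds along the chain from a sulfur. With both known values resting at the assay boundary (the limit of > 50000 nM in this assay, at which 2 of the 2 values shown sit), no shift beyond the usual scatter is expected in this assay. The expected step is a step that the limit leaves unreadable from compound 2 to compound 3, which means essentially no change. Compound 3 is therefore estimated to give about 60000 nM, within a range from 30000 nM to 150000 nM, and the assay is most likely to return only a limit again.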

Compound 3, half-maximal cytotoxic concentration: > 50000 nM
Compound 3: a limit, no number; the forecaster's own chance of this, stated with the estimate: 85%; the middle value does not contradict the limit.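

The step from compound 2 to compound 3 cannot be read, since both compounds give only a limit in this assay: the limit of > 50000 nM in this assay, at which 3 of the 3 values shown sit.
The compounds shown leave open whether replacing 3-chloropropyl with propyl changes cytotoxicity at all, as none of them gives a number here.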